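Swapping tert-butyl for nitro on the outer phenyl ring

The compounds below may be only part of what the source reports. "The series", "measured", "known", "first", "only" and "open" are said of these compounds alone.

Compound 1 `O=c1ccoc2cc(OCc3cn(Cc4cccc(F)c4)nn3)ccc12`, compound 2 `O=c1ccoc2cc(OCc3cn(Cc4ccccc4F)nn3)ccc12` and compound 3 `CC(C)(C)c1ccc(Cn2cc(COc3ccc4c(=O)ccoc4c3)nn2)cc1` share one core and differ only in the group carried on an outer six-membered aromatic ring of carbon only. In a functional assay on A549 cells (Homo sapiens) for cytotoxicity, read by MTT assay, with a stated time of 48 h (a lower number here means a stronger inhibitor, a higher number a weaker inhibitor), compound 1 reaches only the limit of the assay, > 100000 nM. In this assay compound 2 gives 10800 nM. Compound 3 also stops at the limit, > 100000 nM, so for compound 3 no number is known, only that it sits at the limit of > 100000 nM in this assay, at which 2 of the 3 values shown sit.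

Going by the values given here, the one measured step, an at least 9.2-fold lower number from compound 1 to compound 2 (0.96 log units; beyond the scatter), concerns moving a fluorine around the ring, not the group carried by compound 3. Compound 4 `O=c1ccoc2cc(OCc3cn(Cc4ccc([N+](=O)[O-])cc4)nn3)ccc12` differs from compound 3 by nitro in place of tert-butyl on an aromatic carbon. Among the compounds with values here, no measured step speaks to this exchange, so the step from compound 3 is expected to be small, a number no higher from compound 3 to compound 4 (the limit leaves the size open), with the value remaining near the limit. Compound 4 is therefore estimated at 100000 nM, within a range from 20000 nM to 300000 nM.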

Compound 4, half-maximal inhibitory concentration: > 100000 nM
Compound 4 ended at the assay's limit (the forecaster's own chance of this, stated with the estimate: 60%); the middle value sits exactly at the limit.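

In this assay, the nitro group leaves compound 4 at a limit of the assay and not at a number, as tert-butyl did for compound 3, so the steps joining compound 4 to compound 3 and to compound 1 cannot be read. Going by these compounds alone, the one readable step is an at least 9.2-fold higher number from compound 2 to compound 4 (0.96 log units; beyond the scatter), which sets 4-nitrophenyl against 2-fluorophenyl. Compound 2 therefore remains the only compound here with a measured number, and the others share one limit: the limit of > 100000 nM in this assay, at which 3 of the 4 values shown sit.

The compounds shown leave open whether an amine or a carboxylic acid on the outer phenyl ring, in the place held by nitro and tert-butyl, would give a measurable number. They also cannot tell whether compound 1, compound 3 and compound 4 differ from one another at all.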